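This account rests on a few compounds, and the source may have more. Where it says the series, first, only, none or still open, it means among the compounds named here.

Measured so far in an assay on HEK293 cells for inhibition of Steryl-sulfatase (Homo sapiens), tested at 0.1 uM; a higher number here means a stronger effect of the compound at the concentration tested, a lower number a weaker effect:

compound 1 `CN(C)CCN(CCN(C)C)c1ccc(C(=O)N2CCc3ccc(OS(N)(=O)=O)cc3C2)cc1` gives 3.8%
compound 2 `CN(C)CCCN(Cc1ccccc1)c1cccc(C(=O)N2CCc3ccc(OS(N)(=O)=O)cc3C2)c1` gives 23.8%
compound 3 `CCN(Cc1ccccc1)Cc1ccc(CN2CCc3ccc(OS(N)(=O)=O)cc3C2)cc1` gives 1%

All three compounds share the same core carrying the sulfamate group, and all three show only weak inhibition at the single concentration tested. Compound 1 stands second highest of the three numbers. Its nearest neighbour is compound 3, whose value lies within the usual scatter of this kind of measurement, so the two cannot be told apart. Compound 2 is the furthest away, with a value beyond the scatter above compound 1.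

The step from compound 1 to compound 4 `CN(CCN1CCCCC1)c1ccc(C(=O)N2CCc3ccc(OS(N)(=O)=O)cc3C2)cc1` changes the amino group on the aromatic ring: methyl(2-(piperidin-1-yl)ethyl)amino in place of bis(2-(dimethylamino)ethyl)amino on an aromatic carbon. A methyl(2-(piperidin-1-yl)ethyl)amino group takes the place of the bis(2-(dimethylamino)ethyl)amino group, at the position para to a large group. For the measured compounds named here, no measured pair shows this kind of change, so there is no directly comparable step to lean on. Because compound 1 gives 3.8%, a step of no more than the scatter is expected in this assay, in either direction, and the estimated step is a number 2.2 percentage points higher from compound 1 to compound 4 (within the scatter). Compound 4 is therefore expected to give about 6%, in a range from 0% to 20%.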

Compound 4, a percentage reported as inhibition, at one concentration (the size of the read-out at that concentration, not a potency): 0.3%
Compound 4: middle estimate off by 5.7 percentage points, on the high side; low and high end bracket the measured number.
By their numbers in this assay, from the lowest: compounds 4, 3 and 1 (each within the scatter of the next); then compound 2.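

In this assay, putting methyl(2-(piperidin-1-yl)ethyl)amino in place of bis(2-(dimethylamino)ethyl)amino on the aromatic carbon gives a number 3.5 percentage points lower from compound 1 to compound 4 (within the scatter), the first step measured between two compounds that differ in only one place. At this position, then, replacing the open dimethylamino chains with a six-membered non-aromatic ring produces no change that can be told from scatter, with compound 1 at 3.8% and compound 4 at 0.3%, both weak readings at the concentration tested. Nothing measured here accounts for this result.

As far as these compounds go, whether a morpholine ring or a simple primary amine at this position would give a stronger reading remains open. Compound 2 differs from compound 1 in more than one place, so its reading cannot be tied to any single feature.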